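A few compounds are considered here, and "the series" means these few. Any claim that something is new, unique, unknown or untested is made for them only; others in the source may bear on it.

Measured compounds:
- compound 1, `COc1cc(N(C)C(=O)c2ccccc2)cc(OC)c1OC`; in a functional assay on ONS-76 cells (Homo sapiens) for cytotoxicity, read by MTT assay, with a stated time of 72 h (a higher number here means a weaker inhibitor, a lower number a stronger inhibitor), compound 1 gives >= 125000 nM, which is a limit of the assay, not a number.
- compound 2, `COc1cc(N(C)C(=O)c2ccc(F)cc2)cc(OC)c1OC`; in this assay compound 2 gives >= 125000 nM, again a limit.
- compound 3, `COc1cc(N(C)C(=O)c2ccc([N+](=O)[O-])cc2)cc(OC)c1OC`; in this assay compound 3 gives >= 125000 nM, also a limit.

Compound 3 therefore stands only at the limit, as do the other two members of the series; all three sit at the limit of >= 125000 nM in this assay, at which 3 of the 3 values shown sit, so no ordering among them can be read. The steps from compound 1 to compound 2 (a step that the two limits leave unreadable from compound 1 to compound 2), from compound 1 to compound 3 (a step that the two limits leave unreadable from compound 1 to compound 3) and from compound 2 to compound 3 (a step that the two limits leave unreadable from compound 2 to compound 3) are all unreadable for the same reason.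

Compound 4, `COc1ccc(C(=O)N(C)c2cc(OC)c(OC)c(OC)c2)cc1`, is not yet measured. It differs from compound 3 in one place: methoxy in place of nitro on an aromatic carbon. The measured steps that bear on this change are the three above, and none gives a readable size or direction. The expectation for compound 4 in this assay is therefore no step beyond the scatter, with the likely outcome again a limit; the expected step that the limit leaves unreadable from compound 3 to compound 4 is taken as flat. The estimate for compound 4 is 150000 nM, range 60000 nM to 400000 nM.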

Compound 4, half-maximal inhibitory concentration: >= 125000 nM
Compound 4: only a limit was reported (the forecaster's own chance of this, stated with the estimate: 80%); the middle value is on the limit's open side.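

No new step can be read for compound 4 against compound 1, compound 2 or compound 3, as all four stand at one limit in this assay: the limit of >= 125000 nM in this assay, at which 4 of the 4 values shown sit. Whether any change at this place on the shared core brings a measurable value in this assay stays open, as does any ordering among these compounds.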